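Trifluoromethyl in place of benzyl: expected step

A few compounds are considered here, and "the series" means these few. Any claim that something is new, unique, unknown or untested is made for them only; others in the source may bear on it.

In a functional assay on KG-1 cells (Homo sapiens) for cytotoxicity, read by luminescence and CellTiter-Glo, with a stated time of 3 days (a lower number here means a stronger inhibitor, a higher number a weaker inhibitor), compound 2 (`N#Cc1ccc(NC(=O)c2cc(Cc3ccccc3)ccc2O)cc1`) gives 1930 nM as the lowest of two numbers, and compound 1 (`N#Cc1ccc(NC(=O)c2cc(-c3ccncc3)ccc2O)cc1`) gives 7990 nM as the other. Compound 3 (`N#Cc1ccc(NC(=O)c2cc(C(F)(F)F)ccc2O)cc1`) has trifluoromethyl in place of benzyl on an aromatic carbon. Among the measured compounds shown here, the only measured step is a 4.1-fold lower number from compound 1 to compound 2 (0.62 log units; beyond the scatter) and it offers just a rough scale, since no trifluoromethyl compound has been measured. A step of similar or smaller size is expected, with the direction open. The expected step is a 1.3-fold higher number from compound 2 to compound 3 (0.11 log units; within the scatter) and is not clearly beyond the scatter. Compound 3 is estimated at 2500 nM with an expected range from 800 nM to 8000 nM in this series.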

Compound 3, half-maximal inhibitory concentration: 4810 nM
Compound 3: the middle estimate sits 1.9-fold (0.28 log units) below what was measured, within the range that was stated.
By their numbers in this assay, from the lowest: compound 2; then compounds 3 and 1 (each within the scatter of the next).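

In this assay a group with no ring now stands at this position, and trifluoromethyl in place of benzyl gives a 2.5-fold higher number from compound 2 to compound 3 (0.40 log units; beyond the scatter) so compound 2 keeps the lowest number by a modest margin. Trifluoromethyl in place of pyridin-4-yl gives a 1.7-fold lower number from compound 1 to compound 3 (0.22 log units; within the scatter) so these two groups are not separated here, despite the ring present only in pyridin-4-yl. No available measurement accounts for either step. Open, going by these compounds, is how an amine, a carboxylic acid or a longer chain at this position would compare with benzyl in compound 2.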